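The compounds below may be only part of what the source reports. "The series", "measured", "known", "first", "only" and "open" are said of these compounds alone.

In an assay on isolated protein for inhibition of histone deacetylase 8 (Homo sapiens), read by fluorescence, with a stated time of 10 min (on this read-out lower numbers stand for stronger inhibition and higher numbers for weaker inhibition), three compounds of this series have been measured. Compound 1 `O=C(CCCCCCc1nc(-c2ccc(F)cc2)no1)NO` gives 8760 nM. Compound 2 `Cc1ccc(-c2noc(CCCCCCC(=O)C(F)(F)F)n2)cc1` gives 3190 nM, and compound 3 `COc1ccc(-c2noc(CCCCCCC(=O)C(F)(F)F)n2)cc1` gives 1860 nM, the lowest of the three numbers, although its gap to compound 2 lies within the scatter; only compound 1 stands clearly higher. Among the compounds with values here, the single one-place step recorded so far, a 1.7-fold lower number from compound 2 to compound 3 (0.23 log units; within the scatter), was too small to read as a real change. Compound 4 `O=C(CCCCCCc1nc(-c2ccc(F)cc2)no1)C(F)(F)F` differs from compound 3 in one place: fluoro in place of methoxy on an aromatic carbon. Within the data shown here, no measured pair speaks directly to this exchange. Among the measured compounds shown here, the one step in the same region, methoxy in place of methyl, moved the number little, and compound 1, which also carries the 4-fluorophenyl group but differs from compound 3 in a second place too, gives a higher value. A small step, if any, and tending toward a higher number is therefore expected. For compound 4 the estimate is 2600 nM, within a range from 1000 nM to 6500 nM. This estimate amounts to an expected 1.4-fold higher number from compound 3 to compound 4 (0.15 log units; within the scatter).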

Compound 4, half-maximal inhibitory concentration: 7650 nM
Estimate against measurement, compound 4: 2.9-fold (0.47 log units) below; the measured number lies above the stated range.
By their numbers in this assay, from the lowest: compounds 3 and 2 (each within the scatter of the next); then compounds 4 and 1 (each within the scatter of the next).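

In this assay the aromatic carbon para to a large group proves sensitive to its substituent after all: fluoro in place of methoxy gives a 4.1-fold higher number from compound 3 to compound 4 (0.61 log units; beyond the scatter), and fluoro in place of methyl gives a 2.4-fold higher number from compound 2 to compound 4 (0.38 log units; beyond the scatter), both beyond the scatter. The earlier exchange of methyl for methoxy had stayed within the scatter, so among these three groups only fluoro sets itself apart at this place. With the 4-fluorophenyl group held constant, trifluoromethyl in place of hydroxyamino on the carbonyl carbon gives a 1.1-fold lower number from compound 1 to compound 4 (0.06 log units; within the scatter), within the scatter, so no difference between these two groups can be read in this setting.

Nothing available explains the loss that comes with fluoro at this place. As far as these compounds go, it remains open whether hydroxyamino would match trifluoromethyl alongside the 4-methoxyphenyl group, and how a chloro or an amino group would read on this aromatic carbon.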